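Amine position in the cyclopropanecarboxamide series

The compounds below may be only part of what the source reports. "The series", "measured", "known", "first", "only" and "open" are said of these compounds alone.

Measured compounds in a functional assay for agonist activity at G protein-coupled receptor 88 (Homo sapiens), read by HTRF and cAMP accumulation; on this read-out lower numbers stand for an effect already at smaller amounts and higher numbers for an effect only at larger amounts of compound:
compound 1 `CC(C)C[C@H](N)CN(C(=O)[C@@H]1C[C@H]1c1ccccc1)c1ccc(-c2ccccc2)cc1` gives 880 nM
compound 2 `N[C@@H](CC1CCCCC1)CN(C(=O)[C@@H]1C[C@H]1c1ccccc1)c1ccc(-c2ccccc2)cc1` gives 1.7 nM
compound 3 `CCC(CC)C(N)CCN(C(=O)[C@@H]1C[C@H]1c1ccccc1)c1ccc(-c2ccccc2)cc1` gives 2 nM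

Compound 2 stands lowest of the three numbers in this assay; compound 3 sits within the scatter of it, as a 1.2-fold higher number from compound 2 to compound 3 (0.07 log units; within the scatter) shows, while compound 1 lies far away, as a 520-fold lower number from compound 1 to compound 2 (2.71 log units; beyond the scatter) shows. Compound 4 `O=C([C@@H]1C[C@H]1c1ccccc1)N(CCNCC1CCCCC1)c1ccc(-c2ccccc2)cc1` has not been measured. It keeps all the atoms of compound 2 but joins them differently: ((cyclohexylmethyl)amino)methyl in place of 1-amino-2-cyclohexylethyl on a saturated chain carbon bound to an amide-type nitrogen.

Among the measured compounds shown here, no measured step moves the amine nitrogen into the chain or turns the primary amine into a secondary one, so no step maps directly onto this change. For the measured compounds named here, two steps bear on it indirectly. The large steps of a 520-fold lower number from compound 1 to compound 2 (2.71 log units; beyond the scatter) and a 440-fold lower number from compound 1 to compound 3 (2.64 log units; beyond the scatter) show that this assay reacts strongly to what stands on the carbon near the amine. The small step of a 1.2-fold higher number from compound 2 to compound 3 (0.07 log units; within the scatter) shows that shifting the amine one carbon along the chain, together with a different branched group, costs nothing beyond the scatter. Moving the nitrogen into the chain itself and carrying the cyclohexyl on it is a larger rearrangement than either, so a modest loss is expected for compound 4, a 12-fold higher number from compound 2 to compound 4 (1.07 log units; beyond the scatter), with wide uncertainty. The estimate for compound 4 in this assay is 20 nM, within a range from 3 nM to 200 nM.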

Compound 4, half-maximal effective concentration: 6.6 nM
Beside the measured number, compound 4's estimate is 3.0-fold (0.48 log units) above it; the measured number falls inside the stated range.
By their numbers in this assay, from the lowest: compounds 2 and 3 (each within the scatter of the next); then compound 4; then compound 1.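

In this assay the change from 2-amino-3-cyclohexylpropyl to 2-((cyclohexylmethyl)amino)ethyl carries only a modest cost (a 3.9-fold higher number from compound 2 to compound 4 (0.59 log units; beyond the scatter)), and the gap to the 2-amino-3-ethylpentyl compound is of similar size (a 3.3-fold higher number from compound 3 to compound 4 (0.52 log units; beyond the scatter)). A low number therefore needs neither a primary amine nor the defined stereocentre of compound 2, since compound 4 is a secondary amine without one and still retains most of the gain over the isobutyl-bearing compound (a 130-fold lower number from compound 1 to compound 4 (2.12 log units; beyond the scatter)). Nothing at hand explains the remaining loss.

Still open, from the compounds shown here alone, is whether the secondary amine depends on its cyclohexylmethyl group. A benzyl or isobutyl group on that nitrogen, or a tertiary amine carrying an added methyl, would test this.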